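Swapping One Halogen for Another on a Phenyl Ring

The source may hold more compounds than are shown below. What is called first, only, known or untested is meant among the compounds shown, and "the series" means these compounds.

Compound 1 `COc1ccccc1/C=c1/[nH]c(=O)/c(=C\c2ccccc2OC)[nH]c1=O`: "not active" (no number reported)
Compound 2 `C=CCn1c(=O)/c(=C\c2cccc(F)c2)[nH]c(=O)/c1=C\c1ccccc1OC`: 5600 nM
Compound 3 `COc1ccccc1/C=c1\c(=O)[nH]/c(=C/c2ccccc2Cl)c(=O)n1C`: 300 nM

Three compounds share a core and differ in the groups attached to it. In a functional assay on BGC-823 cells (Homo sapiens) for cytotoxicity, read by CCK-8 assay, with a stated time of 72 h (a higher number here means a weaker inhibitor, a lower number a stronger inhibitor), compound 1 gives "not active" (no number reported), with no number reported. Compound 2 gives 5600 nM in this assay, and compound 3 gives 300 nM. Of the two numbers, compound 2 stands highest: compound 3 sits well below it, a gap beyond the usual scatter, while compound 1 leaves no number to compare. Compound 2 and compound 3 differ in more than one place, so that gap cannot be tied to any single change.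

Compound 4 `C=CCn1c(=O)/c(=C\c2cccc(Br)c2)[nH]c(=O)/c1=C\c1ccccc1OC` is the next compound. It differs from compound 2 in one place: bromo in place of fluoro on an aromatic carbon. For the measured compounds named here, no measured pair shows what this particular change does, and the nearest measured compounds vary elsewhere as well. With nothing pointing either way, the step of a 1.1-fold lower number from compound 2 to compound 4 (0.05 log units; within the scatter) is expected to stay within the scatter of the method. Compound 4 is therefore estimated at 5000 nM, with a likely range from 2000 nM to 12000 nM.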

Compound 4, half-maximal inhibitory concentration: 5900 nM
For compound 4 the middle estimate is 1.2-fold (0.07 log units) below the measured one; the measured number falls inside the stated range.
By their numbers in this assay, from the lowest: compound 3; then compounds 2 and 4 (each within the scatter of the next).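

For the compounds shown here, compound 2 and compound 4 are the only pair here that differ in one place, so they give a direct reading of a single change. In this assay, putting bromo in place of fluoro on this aromatic carbon, meta to a large group, gives a 1.1-fold higher number from compound 2 to compound 4 (0.02 log units; within the scatter), so at this position the two halogens cannot be told apart by this measurement. No measurement is available that would explain this result.

Going by these compounds, it remains open whether a group of a different kind at this position, such as an amine or a carboxylic acid, would shift the number beyond the scatter. On these data alone, it is also open whether the same exchange of fluoro for bromo would read alike with other groups elsewhere on the shared core.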